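Ring Size of the Sulfonamide Amine and Liver Cell Toxicity

The source may hold more compounds than are shown below. What is called first, only, known or untested is meant among the compounds shown, and "the series" means these compounds.

Measured so far:
- compound 1 `CN1CCN(S(=O)(=O)c2ccc(C3=CC4C(Nc5ccc(OCc6cccc(F)c6)c(Cl)c5)=NC=NC4S3)cc2)CC1`: in a toxicity assay on HepG2 cells (Homo sapiens) for cytotoxicity, read by MTT assay, with a stated time of 48 h (on this read-out lower numbers stand for higher toxicity in this test and higher numbers for lower toxicity in this test), compound 1 gives > 15 uM, a limit of the assay.
- compound 2 `CN1CCCN(S(=O)(=O)c2ccc(-c3ccc4ccnc(Nc5ccc(OCc6cccc(F)c6)c(Cl)c5)c4c3)cc2)CC1`: in this assay compound 2 gives > 15 uM, also a limit.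
- compound 3 `CN1CCN(S(=O)(=O)c2ccc(-c3ccc4ccnc(Nc5ccc(OCc6cccc(F)c6)c(Cl)c5)c4c3)cc2)CC1`: in this assay compound 3 gives > 15 uM, again a limit.

Compound 2 differs from compound 3 by 4-methyl-1,4-diazepan-1-yl in place of 4-methylpiperazin-1-yl on a sulfonyl sulfur; the step that the two limits leave unreadable from compound 3 to compound 2 cannot be read because of the limit of > 15 uM in this assay, at which 3 of the 3 values shown sit. The difference between the cores of compound 1 and compound 3 is not broken down here. Compound 4 `CN1CCCN(S(=O)(=O)c2ccc(C3=CC4C(Nc5ccc(OCc6cccc(F)c6)c(Cl)c5)=NC=NC4S3)cc2)CC1` carries the same change on the core of compound 1: 4-methyl-1,4-diazepan-1-yl in place of 4-methylpiperazin-1-yl on a sulfonyl sulfur. The step that the limit leaves unreadable from compound 1 to compound 4 is expected to be small, resting on compound 3 and compound 2 sitting at the same limit. Compound 4 is therefore estimated at 30 uM, most likely reported as a limit again.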

Compound 4, half-maximal toxic concentration: > 15 uM
Compound 4: a limit, no number (the forecaster's own chance of this, stated with the estimate: 85%); the middle value is on the limit's open side.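

The change from compound 1 to compound 4 cannot be sized, because both values are limits, not numbers: the limit of > 15 uM in this assay, at which 4 of the 4 values shown sit. The compounds shown leave open at what concentration any of them becomes toxic in this assay, and whether ring size matters there.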